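Moving a phenol hydroxyl on a shared pyridine core

The source may hold more compounds than are shown below. What is called first, only, known or untested is meant among the compounds shown, and "the series" means these compounds.

Compound 1 `Oc1ccc(-c2cc(-c3cccs3)cc(-c3ccccc3O)n2)cc1`: > 50000 nM
Compound 2 `Oc1ccc(-c2cc(-c3cccs3)cc(-c3cccc(O)c3)n2)cc1`: 4140 nM
Compound 3 `Oc1cccc(-c2cc(-c3cccnc3)cc(-c3ccccc3O)n2)c1`: 7530 nM

In a functional assay on HeLa cells (Homo sapiens) for cytotoxicity, read by CCK-8 assay (a higher number here means a weaker inhibitor, a lower number a stronger inhibitor), compound 1 gives only a limit, > 50000 nM. Compound 2 reaches 4140 nM in this assay, and the step is an at least 12-fold lower number from compound 1 to compound 2 (1.08 log units; beyond the scatter), with the change (3-hydroxyphenyl in place of 2-hydroxyphenyl on an aromatic carbon); its true size is open because of the limit of > 50000 nM in this assay, at which 1 of the 3 values shown sits. Compound 3 gives 7530 nM in this assay; how the core of compound 3 differs from that of compound 1 is not broken down here. Compound 4 `Oc1cccc(-c2cc(-c3cccnc3)cc(-c3cccc(O)c3)n2)c1` is not yet measured. It differs from compound 3 by 3-hydroxyphenyl in place of 2-hydroxyphenyl on an aromatic carbon, the same kind of change as before, though here the place is meta to a 3-hydroxyphenyl group and a pyridin-3-yl group rather than a 4-hydroxyphenyl and a thiophen-2-yl group. Resting on the step of an at least 12-fold lower number from compound 1 to compound 2 (1.08 log units; beyond the scatter), compound 4 is expected to show a 6.3-fold lower number from compound 3 to compound 4 (0.80 log units; beyond the scatter). The estimate for compound 4 is 1200 nM, between 300 nM and 5000 nM.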

Compound 4, half-maximal inhibitory concentration: > 50000 nM
Compound 4 gave a limit, no number; the forecaster's own chance of this, stated with the estimate: 3%; middle value at least 41-fold (1.61 log units) from the limit.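

In this assay, the change to 3-hydroxyphenyl on the core of compound 3 gives an at least 6.6-fold higher number from compound 3 to compound 4 (0.82 log units; beyond the scatter), so the earlier gain does not carry over to this core. The two steps run in opposite directions: the same change on two cores in this assay, an at least 12-fold lower number (1.08 log units; beyond the scatter) from compound 1 to compound 2 and an at least 6.6-fold higher number (0.82 log units; beyond the scatter) from compound 3 to compound 4, at least 80-fold (1.90 log units) apart, beyond the scatter of two such steps Which difference between the cores turns the step around, the 4-hydroxyphenyl and thiophen-2-yl groups of one or the 3-hydroxyphenyl and pyridin-3-yl groups of the other, is not shown, and the true size of each step stays open: the limit of > 50000 nM in this assay, at which 2 of the 4 values shown sit.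

The compounds shown leave open how the step would behave with only one of those groups exchanged. They also leave open what a methoxy group or an amine in place of the phenol hydroxyl would do on either core.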